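From piperidin-1-yl to isopropylamino on a saturated chain

This account rests on a few compounds, and the source may have more. Where it says the series, first, only, none or still open, it means among the compounds named here.

Compound 3 (`CC(C)=CCc1cc(C(=O)Nc2cc3ccc(OCCCN4CCCCC4)c(C)c3oc2=O)ccc1O`) stands in a functional assay on MCF7 cells (Homo sapiens) for antiproliferative activity (a lower number here means a stronger inhibitor, a higher number a weaker inhibitor), at > 50000 nM, which is a limit of the assay and not a number. Compound 4 (`CC(C)=CCc1cc(C(=O)Nc2cc3ccc(OCCCNC(C)C)c(C)c3oc2=O)ccc1O`) carries isopropylamino in place of piperidin-1-yl on a saturated chain carbon, three bonds along the chain from an oxygen on an aromatic ring. Going by the values given here, only one measured step bears on a change at an amine. In this assay compound 1 (`CC(=O)Oc1ccc(C(=O)Nc2cc3ccc(OCC4CCCN(C)C4)c(C)c3oc2=O)cc1CC=C(C)C`) gives 1650 nM and compound 2 (`CC(=O)Oc1ccc(C(=O)Nc2cc3ccc(OCC4CCCNC4)c(C)c3oc2=O)cc1CC=C(C)C`) gives 820 nM. Hydrogen in place of methyl on an amine nitrogen in a ring there amounts to a 2.0-fold lower number from compound 1 to compound 2 (0.30 log units; within the scatter), so only a modest shift is expected here, towards a lower number, and another limit remains likely. The expected step is an at least 1.6-fold lower number from compound 3 to compound 4 (0.22 log units; that floor lies within the scatter). Compound 4 is estimated at 30000 nM (range 6000 nM to 50000 nM).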

Compound 4, half-maximal inhibitory concentration: 740 nM
Compound 4: the middle estimate sits 41-fold (1.61 log units) above what was measured, and the stated range ends above it.
By their numbers in this assay, from the lowest: compounds 4, 2 and 1 (each within the scatter of the next, the first and the last beyond it). At a limit, above all of these: compound 3.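

Replacing 3-(piperidin-1-yl)propyl with 3-(isopropylamino)propyl is the first change shown to reach beyond the scatter in this assay: it gives an at least 67-fold lower number from compound 3 to compound 4 (1.82 log units; beyond the scatter). Compound 3 gives > 50000 nM, a limit of the assay and not a number, so the step has only a floor: the limit of > 50000 nM in this assay, at which 1 of the 4 values shown sits. The amine at this chain end therefore matters far more here than the step at the ring nitrogen, which stayed within the scatter.

On these data alone, it remains open whether the hydrogen on the nitrogen or the absence of the ring accounts for the drop. A dimethylamino or pyrrolidin-1-yl group at this chain end would help separate the two.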